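The compounds below may be only part of what the source reports. "The series", "measured", "known", "first", "only" and "open" are said of these compounds alone.

Working notes on the series. Compound 1 `O=C(Nc1cccc(-n2cc(-c3ccncc3)c(-c3cc(O)cc(Cl)c3)n2)c1)Nc1ccc(Cl)c(C(F)(F)F)c1` in a functional assay on UACC-62 cells (Homo sapiens) for inhibition, read by sulforhodamine B assay, with a stated time of 48 h, tested at 10 uM (on this read-out lower numbers stand for a stronger effect and higher numbers for a weaker effect at the one concentration tested), gives -1.44%. Compound 2 `COc1cc(Cl)cc(-c2nn(-c3cccc(NC(=O)Nc4ccc(Cl)c(C(F)(F)F)c4)c3)cc2-c2ccncc2)c1` carries methyl in place of hydrogen on an oxygen on an aromatic ring relative to compound 1, and in this assay compound 2 gives 6.62%; the step is a number 8.1 percentage points higher from compound 1 to compound 2 (within the scatter). Compound 3 `O=C(Nc1cccc(-n2cc(-c3ccncc3)c(-c3cc(O)cc(Cl)c3)n2)c1)c1cc(C(F)(F)F)cc(C(F)(F)F)c1` differs from compound 1 in its core, a difference not broken down here; in this assay compound 3 gives 69.3%, the highest of the three, beyond the scatter from both compound 2 and compound 1. Compound 4 `COc1cc(Cl)cc(-c2nn(-c3cccc(NC(=O)c4cc(C(F)(F)F)cc(C(F)(F)F)c4)c3)cc2-c2ccncc2)c1` is unmeasured and carries methyl in place of hydrogen on an oxygen on an aromatic ring relative to compound 3, the same change as from compound 1 to compound 2. The expected step of a number 2.7 percentage points higher from compound 3 to compound 4 (within the scatter) is taken to stay within the scatter because a number 8.1 percentage points higher from compound 1 to compound 2 (within the scatter) showed only that. For compound 4 in this assay the estimate is 72%, between 55% and 88%.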

Compound 4, a percentage reported as activity, at one concentration (the size of the read-out at that concentration, not a potency): 81.4%
For compound 4 the middle estimate is 9.4 percentage points below the measured one, and the stated range covers the measured number.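

In this assay the change from hydroxy to methoxy gives a number 12.1 percentage points higher from compound 3 to compound 4 (beyond the scatter) and so stands on the weaker side on the core of compound 3, as it does on the core of compound 1. Carried from one core to the other, the change keeps its direction, and the two steps cannot be told apart in size: the same change on two cores in this assay, a number 8.1 percentage points higher (within the scatter) from compound 1 to compound 2 and a number 12.1 percentage points higher (beyond the scatter) from compound 3 to compound 4, 4 percentage points apart, within the scatter of two such steps. This rests on two pairs at a single concentration in one cell line, and it does not show that the change would carry to any further core.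

Open, from the compounds shown here alone, is what an ethoxy group or a longer chain on that oxygen would give. Going by these compounds, an amine or a carboxylic acid in place of the hydroxy group also remains open.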